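This account rests on a few compounds, and the source may have more. Where it says the series, first, only, none or still open, it means among the compounds named here.

In a functional assay on MCF7 cells (Homo sapiens) for inhibition, read by MTT assay (on this read-out lower numbers stand for stronger inhibition and higher numbers for weaker inhibition), compound 1 `CCc1ccc(C(=O)Nc2ccc(Nc3ncnc4cc(OC)c(OC)cc34)cc2)cc1` gives 65000 nM. Compound 3 `COc1cc2ncnc(Nc3ccc(NC(=O)c4ccccc4I)cc3)c2cc1OC` gives 37000 nM. Compound 2 `COc1cc2ncnc(Nc3ccc(NC(=O)c4ccc(C(C)(C)C)cc4)cc3)c2cc1OC` reads > 100000 nM, which is a limit of the assay and not a number. The two numbered values lie close together, with a 1.8-fold lower number from compound 1 to compound 3 (0.24 log units; within the scatter). Both steps involving the limit are floors: an at least 1.5-fold higher number from compound 1 to compound 2 (0.18 log units; that floor lies within the scatter), and an at least 2.7-fold lower number from compound 2 to compound 3 (0.43 log units; beyond the scatter). Compound 3 therefore sits level with compound 1 within the scatter, and only the second floor clears it.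

Compound 4 `COc1cc2ncnc(Nc3ccc(NC(=O)c4cc(F)ccc4Br)cc3)c2cc1OC` carries 2-bromo-5-fluorophenyl in place of 2-iodophenyl on a carbonyl carbon. Going by the values given here, no measured step isolates this exchange. The nearest guide is the other aryl exchange at that carbonyl carbon, a 1.8-fold lower number from compound 1 to compound 3 (0.24 log units; within the scatter), while the larger floor an at least 2.7-fold lower number from compound 2 to compound 3 (0.43 log units; beyond the scatter) involves 4-(tert-butyl)phenyl and bears less directly. With compound 3 at 37000 nM as the anchor, no change beyond the scatter is expected. The expected step is a 1.1-fold higher number from compound 3 to compound 4 (0.03 log units; within the scatter). Compound 4 is estimated at 40000 nM, with an expected range of 15000 nM to 95000 nM.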

Compound 4, half-maximal inhibitory concentration: 26000 nM
Compound 4: middle estimate off by 1.5-fold (0.19 log units), on the high side; low and high end bracket the measured number.
By their numbers in this assay, from the lowest: compounds 4, 3 and 1 (each within the scatter of the next, the first and the last beyond it). At a limit, above all of these: compound 2.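

In this assay, the exchange on the carbonyl carbon gives a 1.4-fold lower number from compound 3 to compound 4 (0.15 log units; within the scatter), so 2-bromo-5-fluorophenyl and 2-iodophenyl read level at this position. Going by these compounds alone, compound 4 also gives the first numbered step here that clears the scatter, a 2.5-fold lower number from compound 1 to compound 4 (0.40 log units; beyond the scatter), whereas the step to compound 3 stayed within it. The remaining step, an at least 3.8-fold lower number from compound 2 to compound 4 (0.58 log units; beyond the scatter), is only a floor, as compound 2 stands at a limit of the assay and not at a number: the limit of > 100000 nM in this assay, at which 1 of the 4 values shown sits.

The separate contributions of the bromine and the fluorine in compound 4 remain open, as no 2-bromophenyl counterpart stands among these compounds. Also open, as far as these compounds go, is how this position responds to an amine or a carboxylic acid on the aryl ring, or to a pyridine ring in place of the phenyl.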